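Fluoro to chloro swap repeated on a second core

A few compounds are considered here, and "the series" means these few. Any claim that something is new, unique, unknown or untested is made for them only; others in the source may bear on it.

Compound 1 `N=C(N)Nc1cccc(C(=O)NNC(=O)NC(CC(=O)O)c2ccc(F)cc2)c1` and compound 2 `N=C(N)Nc1cccc(C(=O)NNC(=O)NC(CC(=O)O)c2ccc(Cl)cc2)c1` share one core; compound 3 `O=C(O)CC(NC(=O)NNC(=O)CCCCNc1ccccn1)c1ccc(F)cc1` and compound 4 `O=C(O)CC(NC(=O)NNC(=O)CCCCNc1ccccn1)c1ccc(Cl)cc1` share another. The difference between the two cores is not broken down here. In a physicochemical assay for lipophilicity (on this read-out higher numbers stand for higher lipophilicity and lower numbers for lower lipophilicity), compound 1 gives 0.86 and compound 2 gives 1.26. In this assay compound 3 gives 1.8, the highest of the three measured numbers, with compound 2 nearer to it than compound 1.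

Among the compounds with values here, the one change within the first pair, (chloro in place of fluoro on an aromatic carbon), made a number 0.40 log units higher from compound 1 to compound 2 (beyond the scatter). Compound 4 differs from compound 3 by chloro in place of fluoro on an aromatic carbon; the place of the change reads the same in both pairs, so this is the same change, now on the second core. Among the compounds shown the change occurs twice in all, and only the first occurrence is measured.

Within the data shown here, the step expected in this assay from compound 3 to compound 4 is a number 0.40 log units higher from compound 3 to compound 4 (beyond the scatter), set beside the earlier one because a number 0.40 log units higher from compound 1 to compound 2 (beyond the scatter) is the only measured instance of this change; the single precedent is the sole basis, and any effect of the different core on the step size cannot be read from the data here. Compound 4 is therefore estimated at 2.2 in this assay, expected to lie between 1.9 and 2.5.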

Compound 4, partition coefficient: 2.2
Compound 4: middle estimate and measured number agree at the digits printed, within the range that was stated.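

In this assay chloro in place of fluoro on an aromatic carbon gives a number 0.40 log units higher from compound 3 to compound 4 (beyond the scatter) and, on the core of compound 1, gave a number 0.40 log units higher from compound 1 to compound 2 (beyond the scatter) as well, so the step has the same size on both cores at the digits printed. Within the data shown here, this rests on only two matched pairs, one for each core, and it does not show that the step would carry over to a third core, that it would hold in any other read-out, or that other changes at this place would transfer in the same way between these cores. No measurement shown here offers an explanation for the agreement between the two steps.

The compounds shown leave open whether bromo or methoxy in the same place would also give one step size on both cores, since the 4-fluorophenyl to 4-chlorophenyl change is the only one seen twice. They also leave open whether the step would stay the same on a version of the second core with a longer chain, or with a methyl ester in place of the carboxylic acid.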